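The compounds below may be only part of what the source reports. "The series", "measured", "known", "first", "only" and "open" are said of these compounds alone.

Compound 2 `CC(=O)c1ccc(N2CCN(C(=O)c3oc(C)nc3-c3ccccc3)CC2)cc1` was examined in a functional assay on HL-60 cells (Homo sapiens) for inhibition, read by MTT assay, with a stated time of 72 h (on this read-out higher numbers stand for weaker inhibition and lower numbers for stronger inhibition), and gives "not active" (no number reported), so no single number stands for it, and compound 1 `CCc1nc(-c2ccc(C(C)(C)C)cc2)c(C(=O)N2CCN(c3cccc(OC)c3)CC2)o1` shares this position, giving "not active" (no number reported) as well. Only compound 3 `CCc1nc(-c2cccc(F)c2)c(C(=O)N2CCN(c3cccc(Cl)c3)CC2)o1` carries a number in this assay, where compound 3 gives 317 nM. Compound 4 `Cc1nc(-c2ccccc2)c(C(=O)N2CCN(c3c(C)cccc3C)CC2)o1` has not yet been measured. From compound 2 it differs in one place: 2,6-dimethylphenyl in place of 4-acetylphenyl on an amine nitrogen in a ring. Within the data shown here, no measured pair shows the size of such a step in this assay, so the direction cannot be read from the data; with compound 2 reported without a number, a modest gain toward measurable inhibition seems possible but uncertain. Compound 4 is expected to give an estimated 6000 nM in this assay, within a range of 800 nM to 30000 nM.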

Compound 4, half-maximal inhibitory concentration: 146 nM
Compound 4: middle estimate off by 41-fold (1.61 log units), on the high side; measured number below the stated range.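

Among these compounds, compound 2 carries no number, so no step to compound 4 can be read from this result. No measurement shown offers an explanation for it. The compounds shown leave open how much the 2,6-dimethylphenyl group alone contributes to the value of compound 4.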